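A few compounds are considered here, and "the series" means these few. Any claim that something is new, unique, unknown or untested is made for them only; others in the source may bear on it.

Measured compounds in a functional assay on HEK293 cells for positive allosteric modulation of metabotropic glutamate receptor 5 (Homo sapiens), read by calcium flux; a lower number here means a smaller maximal response, a higher number a larger maximal response:
Compound 1, `O=C1c2cc(COc3ccccc3)nn2CCN1c1ccccc1F`, gives 86%.
Compound 2, `O=C1c2cc(COc3ccccc3)nn2CCN1c1ccc(F)c(F)c1`, gives 81%.
Compound 3, `O=C1c2cc(COc3ccccc3)nn2CCN1c1ccccn1`, gives 69%.

Among these three, compound 3 stands lowest in this assay. The nearest number is that of compound 2, and the step of a number 12 percentage points lower from compound 2 to compound 3 (beyond the scatter) is beyond the scatter; the furthest is that of compound 1, with a number 17 percentage points lower from compound 1 to compound 3 (beyond the scatter) also beyond the scatter. The step of a number 5 percentage points lower from compound 1 to compound 2 (within the scatter), by contrast, lies within the scatter.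

Compound 4, `O=C1c2cc(COc3ccccc3)nn2CCN1c1ncc(F)cn1`, has not yet been measured. It differs from compound 3 in one place: 5-fluoropyrimidin-2-yl in place of pyridin-2-yl on an amide-type nitrogen in a ring. The measured steps bear on this change only loosely. Both a number 17 percentage points lower from compound 1 to compound 3 (beyond the scatter) and a number 12 percentage points lower from compound 2 to compound 3 (beyond the scatter) show that the entry of pyridin-2-yl brought the largest response down modestly, whereas a number 5 percentage points lower from compound 1 to compound 2 (within the scatter) shows that adding a fluorine to a phenyl ring left the number within the scatter. Going by the values given here, no measured pair compares a pyridin-2-yl with a pyrimidin-2-yl, so the expectation for compound 4 must stay cautious: a step from compound 3 that is expected to be small, probably within the scatter, with at most a slight further lowering, a number 4 percentage points lower from compound 3 to compound 4 (within the scatter).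

Compound 4 is therefore expected to give about 65% in this assay, within a range from 50% to 80%.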

Compound 4, largest response reached (Emax), in percent of the reference or control that the assay uses: 72%
Estimate against measurement, compound 4: 7 percentage points below, and the stated range covers the measured number.
By their numbers in this assay, from the lowest: compounds 3, 4, 2 and 1 (each within the scatter of the next, the first and the last beyond it).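

In this assay, the step of a number 3 percentage points higher from compound 3 to compound 4 (within the scatter) shows that, on this amide-type nitrogen in a ring, 5-fluoropyrimidin-2-yl can take the place of pyridin-2-yl, bringing a second ring hetero atom and a fluorine, without leaving the scatter. The step of a number 9 percentage points lower from compound 2 to compound 4 (within the scatter) adds something that compound 3 did not show: unlike pyridin-2-yl, 5-fluoropyrimidin-2-yl stays within the scatter of 3,4-difluorophenyl. Against 2-fluorophenyl, however, the step of a number 14 percentage points lower from compound 1 to compound 4 (beyond the scatter) shows that the gap beyond the scatter seen with pyridin-2-yl also holds for this ring with two hetero atoms.

The data at hand offer no explanation for any of these differences. As far as these compounds go, it remains open what the second ring nitrogen and the fluorine each contribute alone, as an unsubstituted pyrimidin-2-yl would begin to show, and whether a saturated group such as cyclohexyl or tetrahydropyran-4-yl on this nitrogen would keep the response of the aromatic rings.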